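Branching the Hydroxy Ester Chain of Compound 3

The source may hold more compounds than are shown below. What is called first, only, known or untested is meant among the compounds shown, and "the series" means these compounds.

Measured so far:
Compound 1 `CC(C)=CC[C@@H](OC[C@H](C)O)C1=CC(=O)c2c(O)ccc(O)c2C1=O` in a functional assay on DU-145 cells (Homo sapiens) for cytotoxicity, read by MTT assay (on this read-out higher numbers stand for weaker inhibition and lower numbers for stronger inhibition), gives 24500 nM.
Compound 2 `CC(C)=CC[C@@H](OC(=O)CC(C)(O)c1ccccc1)C1=CC(=O)c2c(O)ccc(O)c2C1=O` reaches only a limit of the assay, > 100000 nM.
Compound 3 `CCCC(O)CC(=O)O[C@H](CC=C(C)C)C1=CC(=O)c2c(O)ccc(O)c2C1=O` likewise reaches only a limit, > 100000 nM.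

Compound 3 therefore stands at the weak end of what this assay can report, together with compound 2 (the limit of > 100000 nM in this assay, at which 2 of the 3 values shown sit). The step of an at least 4.0-fold higher number from compound 1 to compound 3 (0.61 log units; beyond the scatter) is the only readable one; the step that the two limits leave unreadable from compound 2 to compound 3 cannot be sized. Compound 4 `CCC(O)(CC)CC(=O)O[C@H](CC=C(C)C)C1=CC(=O)c2c(O)ccc(O)c2C1=O` differs from compound 3 in one place: 1-ethyl-1-hydroxypropyl in place of 1-hydroxybutyl on a saturated chain carbon bound to a carbonyl carbon. For the measured compounds named here, no measured step speaks to this change, and both neighbours of the ester type sit at the limit, so no step beyond the scatter is expected, a step that the limit leaves unreadable from compound 3 to compound 4. Compound 4 is estimated at 150000 nM, between 50000 nM and 400000 nM.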

Compound 4, half-maximal inhibitory concentration: 67000 nM
Beside the measured number, compound 4's estimate is 2.2-fold (0.35 log units) above it; the range from low to high includes it.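

Compound 4, with 1-ethyl-1-hydroxypropyl on the saturated chain carbon bound to a carbonyl carbon, gives a real number in this assay, while compounds 2 and 3 stay at a limit: the limit of > 100000 nM in this assay, at which 2 of the 4 values shown sit. Against those two neighbours, the readings are an at least 1.4-fold lower number from compound 3 to compound 4 (0.17 log units; that floor lies within the scatter) and an at least 1.4-fold lower number from compound 2 to compound 4 (0.17 log units; that floor lies within the scatter), so neither floor shows a gain beyond the scatter. The gap to the 2-hydroxypropyl group, until now only a floor, has a size: a 2.7-fold higher number from compound 1 to compound 4 (0.44 log units; beyond the scatter).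

On these data alone, whether an amine or a carboxylic acid on that chain carbon would bring the number down further remains open.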